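Replacing a fluorinated aryl with a benzyl on the thioether

The source may report more compounds than this note shows. Statements on the series, on what has been measured and on what is new or still open speak of the compounds shown alone.

Going by the values given here, compound 3 `Cc1cc(Nc2cc(-c3ccccc3)[nH]n2)n2nc(SCc3ccc(F)cc3)nc2n1` gives 8110 nM in a functional assay on PC-9 cells (Homo sapiens) for inhibition, read by MTT assay, with a stated time of 72 h (on this read-out higher numbers stand for weaker inhibition and lower numbers for stronger inhibition), which places it second highest of the three numbers known so far, though all three lie within the scatter of one another. Compound 1 `Cc1cc(Nc2cc(-c3ccccc3)[nH]n2)n2nc(SCc3ccc([N+](=O)[O-])cc3)nc2n1` gives 7980 nM in this assay, and compound 2 `Cc1cc(Nc2cc(-c3ccccc3)[nH]n2)n2nc(SCc3cccc(Br)c3)nc2n1` gives 8900 nM. The steps between them, a 1.1-fold higher number from compound 1 to compound 2 (0.05 log units; within the scatter), a 1.0-fold higher number from compound 1 to compound 3 (0.01 log units; within the scatter) and a 1.1-fold lower number from compound 2 to compound 3 (0.04 log units; within the scatter), show that swapping the aryl group on the saturated chain carbon bound to a sulfur has so far left the read-out unchanged. Compound 4 `Cc1cc(Nc2cc(-c3ccccc3)[nH]n2)n2nc(SCCc3ccccc3)nc2n1` differs from compound 3 by benzyl in place of 4-fluorophenyl on a saturated chain carbon bound to a sulfur. Since every comparable change stayed flat, compound 4 is expected to remain within the scatter, with a 1.0-fold higher number from compound 3 to compound 4 (0.02 log units; within the scatter). Compound 4 is therefore estimated at 8500 nM in this assay, in the range 4000 nM to 18000 nM.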

Compound 4, half-maximal inhibitory concentration: 4930 nM
The estimate for compound 4 lay 1.7-fold (0.24 log units) above the measured number, within the range that was stated.
By their numbers in this assay, from the lowest: compounds 4, 1, 3 and 2 (each within the scatter of the next).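

Compound 4 puts benzyl, with no substituent on its ring, on the saturated chain carbon bound to a sulfur, and in this assay the steps to it are a 1.6-fold lower number from compound 3 to compound 4 (0.22 log units; within the scatter) and a 1.8-fold lower number from compound 2 to compound 4 (0.26 log units; within the scatter) and a 1.6-fold lower number from compound 1 to compound 4 (0.21 log units; within the scatter) as well. The flat picture at this position therefore extends from the substituted phenyl groups to benzyl, with no step beyond the scatter. Nothing available bears on the reason for this result.

From the compounds shown here alone, whether an amine, a carboxylic acid or a longer chain at this place would give a step beyond the scatter remains open.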